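The source may hold more compounds than are shown below. What is called first, only, known or untested is meant among the compounds shown, and "the series" means these compounds.

Working notes on the succinimide series, maximal electroshock read-out.

Within the data shown here, compound 1 `CCC(C(=O)N1CCN(c2ccccc2Cl)CC1)N1C(=O)CCC1=O` gives 50% in a functional assay on the whole organism (strain Swiss) with Mus musculus as the target, in the maximal electroshock model, with a stated time of 0.25 h, at a dose of 300 mg/kg by the intraperitoneal route (on this read-out higher numbers stand for a stronger effect at the one dose given and lower numbers for a weaker effect), and stands as the lower of the two numbers so far. Among the measured compounds shown here, compound 2 `CCC(C(=O)N1CCN(c2cccc(C)c2)CC1)N1C(=O)CCC1=O` gives 100% in this assay; the single measured step, a number 50 percentage points higher from compound 1 to compound 2 (beyond the scatter), follows a change on the aryl ring of the piperazine and is large.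

Compound 3 `CC(C(=O)N1CCN(c2ccccc2Cl)CC1)N1C(=O)CCC1=O` has not yet been measured. It differs from compound 1 by hydrogen in place of methyl on a saturated chain carbon, two bonds along the chain from an amide-type nitrogen in a ring and a carbonyl carbon. For the measured compounds named here, this change sits on the chain that carries the succinimide, far from the aryl ring altered between compound 1 and compound 2; the one measured step therefore does not bear on it, and no pair in hand shows what shortening this chain does to the read-out in this assay.

With nothing to go on beyond compound 1 itself, the expected step of a number 10 percentage points lower from compound 1 to compound 3 (within the scatter) is set modestly downward and with wide uncertainty. Compound 3 is thus expected to give about 40% in this assay, with a range estimated from 10% to 80%.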

Compound 3, a percentage reported as activity, at one dose (the size of the read-out at that dose, not a potency): 0%
For compound 3 the middle estimate is 40 percentage points above the measured one, outside the stated range (below it).
By their numbers in this assay, from the lowest: compound 3; then compound 1; then compound 2.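

The chain that carries the succinimide is not a silent part of the series: with the 2-chlorophenyl group held fixed, going from ethyl to methyl on the saturated chain carbon, the loss of one carbon, gives a number 50 percentage points lower from compound 1 to compound 3 (beyond the scatter). In this assay this single change is printed as large, as is the aryl change from the earlier pair, so the read-out now responds at two separate places on the shared core, and compound 3 sits at 0%, where a lower number cannot show how much further the effect might fall. No measurement here bears on what lies behind this step.

The compounds shown leave open whether the trend runs on past ethyl, since a propyl or a longer chain on this carbon could raise the read-out, hold it or lower it. They also leave open whether ethyl to methyl costs as much on the 3-methylphenyl partner of compound 2, where the read-out starts from the higher value, so that the two changes cannot yet be said to act independently.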